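Swapping Trifluoromethyl for Chloro on a Second Core

This account rests on a few compounds, and the source may have more. Where it says the series, first, only, none or still open, it means among the compounds named here.

Compound 1 `O=S1(=O)C=Cc2ccc(Nc3ccc(C(F)(F)F)cc3)cc21`: 1300 nM
Compound 2 `O=S1(=O)C=Cc2ccc(Nc3ccc(Cl)cc3)cc21`: 6720 nM
Compound 3 `O=S1(=O)C=Cc2cccc(Nc3ccc(C(F)(F)F)cc3)c21`: 1200 nM

All three were tested in a functional assay on MDA-MB-231 cells (Homo sapiens) for antiproliferative activity, read by MTT assay, with a stated time of 72 h; on this read-out higher numbers stand for weaker inhibition and lower numbers for stronger inhibition. Compound 1 and compound 2 share one core and differ by a single change, (chloro in place of trifluoromethyl on an aromatic carbon). That change gave a 5.2-fold higher number from compound 1 to compound 2 (0.71 log units; beyond the scatter). Compound 3 is built from the same atoms as compound 1, joined differently; the difference between the two cores is not broken down here. Compound 3 and compound 1 give numbers within the usual scatter of each other.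

Compound 4 `O=S1(=O)C=Cc2cccc(Nc3ccc(Cl)cc3)c21` has not yet been measured in this assay. It differs from compound 3 by chloro in place of trifluoromethyl on an aromatic carbon, the same change as from compound 1 to compound 2, at the same place. The expected step for compound 4 is a 5.2-fold higher number from compound 3 to compound 4 (0.71 log units; beyond the scatter). This rests on the measured step of a 5.2-fold higher number from compound 1 to compound 2 (0.71 log units; beyond the scatter). Compound 4 is therefore estimated at 6200 nM, expected to lie between 3000 nM and 13000 nM.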

Compound 4, half-maximal inhibitory concentration: 1210 nM
Estimate against measurement, compound 4: 5.1-fold (0.71 log units) above; the measured number lies below the stated range.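

In this assay, replacing trifluoromethyl with chloro on the core of compound 3 gave a 1.0-fold higher number from compound 3 to compound 4 (0.00 log units; within the scatter). For the compounds shown here, the same swap therefore did not carry over in size from one core to the other: the same change on two cores in this assay, a 5.2-fold higher number (0.71 log units; beyond the scatter) from compound 1 to compound 2 and a 1.0-fold higher number (0.00 log units; within the scatter) from compound 3 to compound 4, 5.1-fold (0.71 log units) apart, beyond the scatter of two such steps This shows that a step measured on the core of compound 1 could not be used to predict the step on the core of compound 3, but it does not show why the two cores differ, and each core offers only one such pair.

From the compounds shown here alone, whether a methyl group, a nitrile or an amine in that same place would track the two cores as differently remains open. So does how this swap would behave on any further core.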